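Methyl in place of methoxy: compound 2 to compound 3

This account rests on a few compounds, and the source may have more. Where it says the series, first, only, none or still open, it means among the compounds named here.

In a functional assay on T47D cells (Homo sapiens) for inhibition, read by CCK-8 assay, with a stated time of 72 h, tested at 1 uM (a higher number here means more inhibition of growth at the concentration tested, a lower number less inhibition of growth), compound 1 `CN(C)C(=O)c1cc2cnc(Nc3ccc(NC(=O)C4(C(=O)Nc5cccc(O)c5)CC4)cc3)nc2n1C1CCCC1` gives 80.7%. For the measured compounds named here, in the same read-out, compound 2 `COc1ccc(NC(=O)C2(C(=O)Nc3ccc(Nc4ncc5cc(C(=O)N(C)C)n(C6CCCC6)c5n4)cc3)CC2)cc1` gives 76.4%, which stands within the scatter of compound 1, the only other measured number. The next analogue, compound 3 `Cc1ccc(NC(=O)C2(C(=O)Nc3ccc(Nc4ncc5cc(C(=O)N(C)C)n(C6CCCC6)c5n4)cc3)CC2)cc1`, carries methyl in place of methoxy on an aromatic carbon, para to a large group (methyl in place of methoxy on an aromatic carbon). Going by the values given here, no measured step covers this exact change. Among the compounds with values here, the one step that bears on it, a number 4.3 percentage points lower from compound 1 to compound 2 (within the scatter), alters the aryl group on the same amide-type nitrogen and stays small. On that single step, no shift beyond the scatter is expected in this assay. The expected change, a number 0.4 percentage points lower from compound 2 to compound 3 (within the scatter), is an estimate resting on very little data. For compound 3 the estimated value is 76%, with an expected range of 65% to 85%.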

Compound 3, percent growth inhibition at one concentration: 47.9%
Compound 3: the middle estimate sits 28.1 percentage points above what was measured; measured number below the stated range.
By their numbers in this assay, from the lowest: compound 3; then compounds 2 and 1 (each within the scatter of the next).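

In this assay, methyl in place of methoxy on the aromatic carbon para to a large group gives a number 28.5 percentage points lower from compound 2 to compound 3 (beyond the scatter), so this position is not indifferent to the group it carries, as the earlier pair alone might have suggested. Among these three compounds, 4-methoxyphenyl in place of 3-hydroxyphenyl gives a number 4.3 percentage points lower from compound 1 to compound 2 (within the scatter), whereas 4-methylphenyl in place of 3-hydroxyphenyl gives a number 32.8 percentage points lower from compound 1 to compound 3 (beyond the scatter), so only the aryl group without oxygen stands apart. Nothing at hand explains the loss of growth inhibition.

As far as these compounds go, whether the step follows from losing the oxygen or from the methyl itself stays open, as a single methyl analogue cannot separate the two. An ethoxy, a hydroxy or an amino group on the same carbon would bear on that question.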